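Phosphate to Thiophosphate on a Lipid Phosphate Ligand

This account rests on a few compounds, and the source may have more. Where it says the series, first, only, none or still open, it means among the compounds named here.

Compound 1, `CCCCCCCCOC[C@@H](COP(=O)(O)O)OCCCCCCCC`: 50 nM
Compound 2, `CCCCCCCCNC(=O)[C@@H](COP(=O)(O)O)NC(=O)CCCCCCC`: 489 nM

In an assay on RH7777 cells with lysophosphatidic acid receptor 3 (Homo sapiens) as the target (on this read-out lower numbers stand for stronger inhibition and higher numbers for weaker inhibition), compound 2 gives 489 nM, the highest of the two numbers. Its nearest neighbour, compound 1, gives 50 nM, a gap that lies beyond the scatter. Compound 3 `CCCCCCCCNC(=O)[C@@H](COP(O)(O)=S)NC(=O)CCCCCCC` differs from compound 2 by a group of 4 heavy atoms (2 oxygen, 1 phosphorus, 1 sulfur; no ring) in place of a group of 4 heavy atoms (3 oxygen, 1 phosphorus; no ring), on an oxygen on a saturated carbon. Among the measured compounds shown here, no measured pair in this set shows a step of this kind, so nothing here tells how large it will be. A small step toward a lower number is expected, one that may not reach beyond the scatter. Compound 3 is expected to give about 300 nM in this assay, between 100 nM and 1000 nM, an expected step of a 1.6-fold lower number from compound 2 to compound 3 (0.21 log units; within the scatter).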

Compound 3, inhibition constant: 118 nM
The estimate for compound 3 lay 2.5-fold (0.41 log units) above the measured number; the measured number falls inside the stated range.
By their numbers in this assay, from the lowest: compound 1; then compound 3; then compound 2.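

In this assay, the thiophosphate group in place of the phosphate group gives a 4.1-fold lower number from compound 2 to compound 3 (0.62 log units; beyond the scatter), with the heavy-atom count of the group unchanged. The earlier compounds shown here could not show that this place, on an oxygen on a saturated carbon, responds to sulfur standing in for an oxygen of the group. Nothing available accounts for the size of this step.

On these data alone, it remains open how a carboxylic acid or a phosphonic acid would fare at this place. As far as these compounds go, it is also open whether the same exchange on the core of compound 1 would give a step of similar size.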